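Side-chain variation on a shared core: working notes

The source may report more compounds than this note shows. Statements on the series, on what has been measured and on what is new or still open speak of the compounds shown alone.

Measured so far:
compound 1, `Cc1nc2c(OCc3ccccc3)cccn2c1CCC#N`, 40%
compound 2, `Cc1nc2c(OCc3ccccc3)cccn2c1C[S+](C)[O-]`, 0%
Not yet measured: compound 3, `COC(=O)Cc1c(C)nc2c(OCc3ccccc3)cccn12`

In a functional assay on the whole organism with Rattus norvegicus as the target, with a stated time of 4 h, at a dose of 40 mg/kg by the intraperitoneal route (on this read-out higher numbers stand for more inhibition at the one dose given (going by the name of the read-out) and lower numbers for less inhibition), compound 1 gives 40%, while compound 2 gives 0%. Compound 2 thus stands lowest of the two measured numbers; its nearest neighbour is compound 1, and the gap between them is a number 40 percentage points lower from compound 1 to compound 2 (beyond the scatter). Compound 3 is compound 2 with a group of 4 heavy atoms (2 carbon, 2 oxygen; no ring) in place of a group of 3 heavy atoms (1 carbon, 1 oxygen, 1 sulfur; no ring), on a saturated chain carbon bound to an aromatic carbon. Among the measured compounds shown here, the only measured step that bears on this position is a number 40 percentage points lower from compound 1 to compound 2 (beyond the scatter), the step in which the group now leaving compound 2 entered; that step was large and downward. For the measured compounds named here, with that group gone again and a methoxycarbonyl in its place, a return of part of the lost inhibition is expected, though not of the whole, since no measured compound carries a methoxycarbonyl. Compound 3 is expected to show a step of a number 25 percentage points higher from compound 2 to compound 3 (beyond the scatter). The estimate for compound 3 is 25%, with a range from 0% to 55%.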

Compound 3, a percentage reported as inhibition, in the whole organism at one dose (the size of the read-out at that dose, not a potency): 23%
Estimate against measurement, compound 3: 2 percentage points above; the range from low to high includes it.
By their numbers in this assay, from the lowest: compound 2; then compound 3; then compound 1.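

In this assay the side chain on a saturated chain carbon bound to an aromatic carbon now separates three groups, not two: methoxycarbonyl in place of the sulfur-bearing group gives a number 23 percentage points higher from compound 2 to compound 3 (beyond the scatter) and methoxycarbonyl in place of cyanomethyl gives a number 17 percentage points lower from compound 1 to compound 3 (beyond the scatter) in the same series. Inhibition at this position is therefore not simply present or absent, since methoxycarbonyl lies between the other two groups, with both of its steps beyond the scatter. Nothing available here accounts for this order of the three groups.

Going by these compounds, whether a free carboxylic acid, a primary amide or a longer chain ending in methoxycarbonyl would stand nearer compound 1 or compound 2 remains open. Also open, on these data alone, is whether the same order holds at other doses and times, as all three numbers come from a single dose.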